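Trimethoxyphenyl series: replacing the indolyl arm

The source may hold more compounds than are shown below. What is called first, only, known or untested is meant among the compounds shown, and "the series" means these compounds.

Measured compounds:
compound 1 `Cn1ccc2cc(-c3cc4nccc(-c5ccc(F)cc5)n4n3)ccc21` — 4580 nM
compound 2 `COc1cc(-c2ccnc3cc(-c4ccc5c(ccn5C)c4)nn23)cc(OC)c1OC` — 3 nM
compound 3 `COc1cc(-c2ccnc3cc(-c4cccc5c4ccn5CO)nn23)cc(OC)c1OC` — 1070 nM

Three compounds have been run in a functional assay on MCF7 cells (Homo sapiens) for inhibition, read by CCK-8 assay, with a stated time of 48 h; on this read-out higher numbers stand for weaker inhibition and lower numbers for stronger inhibition. Compound 2 stands lowest of the three numbers; the nearest is compound 3, whose value is higher by a margin beyond the scatter, and compound 1 lies further still, also beyond the scatter. On these figures compound 2 is the most potent member so far.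

The next compound, compound 4 `COc1ccc(-c2cc3nccc(-c4cc(OC)c(OC)c(OC)c4)n3n2)cc1F`, is not yet measured. It keeps the shared core and the trimethoxyphenyl of compound 2 and differs in one place: 3-fluoro-4-methoxyphenyl in place of 1-methyl-1H-indol-5-yl on an aromatic carbon

Going by the values given here, no step between measured compounds tells how much the 1-methyl-1H-indol-5-yl contributes. Compound 1 and compound 3 both carry an indolyl and are weak, so the arm alone does not secure potency. The step from compound 2 to compound 4 is expected to raise the number, beyond the scatter, by a 20-fold higher number from compound 2 to compound 4 (1.30 log units; beyond the scatter). Compound 4 is estimated at 60 nM, within 8 nM to 600 nM.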

Compound 4, half-maximal inhibitory concentration: 183 nM
Estimate against measurement, compound 4: 3.1-fold (0.48 log units) below; the range from low to high includes it.
By their numbers in this assay, from the lowest: compound 2; then compound 4; then compound 3; then compound 1.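

In this assay, going by these compounds alone, placing 3-fluoro-4-methoxyphenyl in place of 1-methyl-1H-indol-5-yl on this aromatic carbon gives a 61-fold higher number from compound 2 to compound 4 (1.79 log units; beyond the scatter), the first reading of what this arm contributes with the rest of the molecule held constant. The step is large, yet compound 4 at 183 nM shows that a single six-membered aromatic ring of carbon only can stand here with the trimethoxyphenyl kept, at a cost that can now be stated for this one pair. No supporting data on hand bear on the origin of this difference.

The compounds shown leave open how much of the step belongs to the fluorine and how much to the methoxy group. They also leave open where a plain phenyl, an aminophenyl or a benzoic acid would fall on this aromatic carbon.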